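Replacing the Amide Aryl Group with Isopropyl

The source may report more compounds than this note shows. Statements on the series, on what has been measured and on what is new or still open speak of the compounds shown alone.

The study compares compounds built on a shared core in a functional assay on A-375 cells (Homo sapiens) for antiproliferative activity, read by MTT assay, with a stated time of 72 h; a lower number here means a stronger inhibitor, a higher number a weaker inhibitor. Compound 1 `COc1ccc(N2C(=O)COc3ccc(-c4cnc5ccccc5c4)cc32)cc1` gives only a limit, > 40000 nM, in this assay. Compound 2 `O=C1COc2ccc(-c3cnc(Cl)c(NS(=O)(=O)c4ccc(F)cc4)c3)cc2N1c1ccc(F)cc1` likewise reaches only a limit of > 40000 nM. Compound 3 `COc1ncc(-c2ccc3c(c2)N(c2ccc(F)cc2)C(=O)CO3)cc1NS(=O)(=O)c1ccc(F)cc1` also stands at a limit of > 40000 nM. Among the compounds with values here, the one single-point change between measured compounds, methoxy in place of chloro on an aromatic carbon, gives a step that the two limits leave unreadable from compound 2 to compound 3. Within the data shown here, every value shown sits at the same limit, (the limit of > 40000 nM in this assay, at which 3 of the 3 values shown sit), so no measured step has a readable size. Compound 4 `COc1ncc(-c2ccc3c(c2)N(C(C)C)C(=O)CO3)cc1NS(=O)(=O)c1ccc(F)cc1` differs from compound 3 by isopropyl in place of 4-fluorophenyl on an amide-type nitrogen in a ring. No measured step touches the amide-type nitrogen, so nothing shown predicts this change, and with all three measured values at the limit the expectation for compound 4 is a step that the limit leaves unreadable from compound 3 to compound 4, most likely still ending at a limit. Compound 4 is therefore estimated at 60000 nM, within a range from 15000 nM to 250000 nM.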

Compound 4, half-maximal inhibitory concentration: 9950 nM
For compound 4 the middle estimate is 6.0-fold (0.78 log units) above the measured one; the whole stated range lies above it.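

In this assay, within the data shown here, the amide-type nitrogen is the first place where a change gives a readable result: isopropyl in place of 4-fluorophenyl gives an at least 4.0-fold lower number from compound 3 to compound 4 (0.60 log units; beyond the scatter). Among these compounds, the earlier compounds could not show this, and the one step among them cannot be read, since all of them sit at the same limit: the limit of > 40000 nM in this assay, at which 3 of the 4 values shown sit. At this position, a group with no ring and fewer heavy atoms than 4-fluorophenyl is therefore compatible with a value clear of that limit, although this one pair cannot separate the loss of the ring from the loss of the fluorine.

As far as these compounds go, whether the gain would carry over to the chloro-bearing compound 2 remains open. From the compounds shown here alone, it is also open how a methyl, a cyclopropyl or a longer chain such as n-butyl on this nitrogen would compare with isopropyl.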